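From a hexyl chain to 4-fluorophenyl on the core

A few compounds are considered here, and "the series" means these few. Any claim that something is new, unique, unknown or untested is made for them only; others in the source may bear on it.

Measured in a functional assay on the whole organism (strain C57B/6) with Mus musculus as the target, in the maximal electroshock model; a higher number here means that more compound is needed for the effect, a lower number that less compound is needed:
- compound 1 `CCCCCCOc1ccc(-n2cnnc2C)cc1` gives 22.8 mg/kg
- compound 2 `CCCCCCOc1ccc(-n2cnnc2CCCC)cc1` gives 13.6 mg/kg
- compound 3 `CCCCCCOc1ccc(-n2cnnc2CCCCCC)cc1` gives only a limit of the assay, > 40 mg/kg

Compound 3 thus has no number of its own in this assay; it sits at the limit of > 40 mg/kg in this assay, at which 1 of the 3 values shown sits. Against the numbered compounds, the change an at least 2.9-fold higher number from compound 2 to compound 3 (0.46 log units; beyond the scatter) is beyond the scatter, whereas a 1.7-fold lower number from compound 1 to compound 2 (0.22 log units; within the scatter) and an at least 1.7-fold higher number from compound 1 to compound 3 (0.24 log units; that floor lies within the scatter) stay within it. The three measured steps all concern the length of a chain on the same carbon of the core.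

Compound 4 `CCCCCCOc1ccc(-n2cnnc2-c2ccc(F)cc2)cc1` differs from compound 3 by 4-fluorophenyl in place of hexyl on an aromatic carbon. Among the measured compounds shown here, no measured step puts an aromatic ring at this place, so the chain steps are only a loose guide: the shorter groups in compound 1 and compound 2 gave numbers, the longest gave a limit. Because compound 3 shows only > 40 mg/kg, any step from it is itself bounded. The estimated step of an at least 1.6-fold lower number from compound 3 to compound 4 (0.20 log units; that floor lies within the scatter) is expected to bring compound 4 back among the numbered compounds, with wide uncertainty. Compound 4 is expected to give about 25 mg/kg, in a range from 9 mg/kg to 70 mg/kg.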

Compound 4, dose for half-maximal effect: 22 mg/kg
The estimate for compound 4 lay 1.1-fold (0.06 log units) above the measured number, within the range that was stated.
By their numbers in this assay, from the lowest: compounds 2, 4 and 1 (each within the scatter of the next). At a limit, above all of these: compound 3.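

In this assay, among the compounds shown here, this carbon of the core, between two ring nitrogen atoms, can carry an aromatic ring and still give a number, and 4-fluorophenyl is the first group here that is not a chain. The ring cannot be told apart from the two shorter chains, as both steps lie within the scatter (a 1.0-fold lower number from compound 1 to compound 4 (0.02 log units; within the scatter)) (a 1.6-fold higher number from compound 2 to compound 4 (0.21 log units; within the scatter)), so methyl, butyl and 4-fluorophenyl all sit at a similar level in this test. For the compounds shown here, the step from the hexyl chain (an at least 1.8-fold lower number from compound 3 to compound 4 (0.25 log units; that floor lies within the scatter)) has a floor within the scatter, so its true size stays unknown, and compound 3 remains the only compound at a limit of the assay: the limit of > 40 mg/kg in this assay, at which 1 of the 4 values shown sits.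

On these data alone, whether the fluorine plays any part stays open, and a plain phenyl group at this place would test that, while an amine or a carboxylic acid here would show whether groups other than carbon chains and fluorinated rings also give a number. The hexyl chain on oxygen is shared by all four compounds, so its contribution cannot be judged from them.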